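Compound 3: tert-butoxy to sec-butoxy

The source may report more compounds than this note shows. Statements on the series, on what has been measured and on what is new or still open speak of the compounds shown alone.

In a functional assay on Hs68 cells (Homo sapiens) for cytotoxicity (on this read-out higher numbers stand for lower toxicity in this test and lower numbers for higher toxicity in this test), compound 2 `CC(C)(C)Oc1ccccc1CNC(=O)c1ccc2cnccc2n1` gives 4.4 ug/mL. Among the measured compounds shown here, its only measured neighbour, compound 1 `CC(C)Oc1ccccc1CNC(=O)c1ccc2cnccc2n1`, gives 2.5 ug/mL, and the two values lie within the scatter of each other, so neither can be ranked above the other. Compound 3 `CC[C@@H](C)Oc1ccccc1CNC(=O)c1ccc2cnccc2n1` has not yet been measured. It keeps the shared core and differs from compound 2 only in the group on the oxygen: sec-butyl in place of tert-butyl on an oxygen on an aromatic ring. This places sec-butyl in place of tert-butyl on an oxygen on an aromatic ring, so the same atoms are joined differently. For the measured compounds named here, only one measured step bears on this change: a 1.8-fold higher number from compound 1 to compound 2 (0.25 log units; within the scatter), a difference that stays within the scatter. Going by the values given here, no measured compound carries a sec-butyl group, so that step offers only indirect guidance. On this evidence, no step beyond the scatter is expected in this assay, and its direction cannot be firmly predicted. The estimated step is a 1.3-fold lower number from compound 2 to compound 3 (0.12 log units; within the scatter). For compound 3, the expected value is 3.3 ug/mL, with an estimated range of 1.7 ug/mL to 6.5 ug/mL.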

Compound 3, half-maximal cytotoxic concentration: 0.1 ug/mL
Beside the measured number, compound 3's estimate is 33-fold (1.52 log units) above it, and the stated range ends above it.
By their numbers in this assay, from the lowest: compound 3; then compounds 1 and 2 (each within the scatter of the next).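

In this assay, the group on the oxygen on an aromatic ring turns out to be far more sensitive to its shape than compound 1 and compound 2 alone suggested: joining the same atoms as sec-butyl rather than tert-butyl gives a 44-fold lower number from compound 2 to compound 3 (1.64 log units; beyond the scatter). The placement of the added methyl also matters, since methyl in place of hydrogen two bonds along the chain from that oxygen gives a 25-fold lower number from compound 1 to compound 3 (1.40 log units; beyond the scatter), both steps beyond the scatter, whereas methyl on the chain carbon bound to the oxygen gave only a 1.8-fold higher number from compound 1 to compound 2 (0.25 log units; within the scatter), within the scatter. Nothing measured here accounts for this sharp rise in toxicity in the test.

Going by these compounds, compound 3 has one defined stereocentre, so it remains open whether the sec-butyl group of opposite configuration would keep so low a number. On these data alone, it is also open whether the effect extends to a straight n-butyl chain, an isobutyl group or a cyclobutyl ring on the same oxygen, or whether it belongs to the sec-butyl group alone.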